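This account rests on a few compounds, and the source may have more. Where it says the series, first, only, none or still open, it means among the compounds named here.

Compound 3 `C/C=C/C(=O)N(Cc1ccc(OC)c(O)c1)c1cc(OC)c(OC)c(OC)c1` stands lowest of the three numbers in a functional assay on HCT-116 cells (Homo sapiens) for inhibition, read by MTT assay, with a stated time of 48 h (on this read-out higher numbers stand for weaker inhibition and lower numbers for stronger inhibition), where compound 3 gives 55 nM. Compound 2 `CCCCC(=O)N(Cc1ccc(OC)c(O)c1)c1cc(OC)c(OC)c(OC)c1` gives 170 nM and compound 1 `COc1ccc(CN(C(=O)CCl)c2cc(OC)c(OC)c(OC)c2)cc1O` gives 250 nM. The change to compound 4 `COc1ccc(CN(C(=O)C(C)C)c2cc(OC)c(OC)c(OC)c2)cc1O` is isopropyl in place of prop-1-en-1-yl on a carbonyl carbon. For the measured compounds named here, the steps that bear on it are a 3.1-fold lower number from compound 2 to compound 3 (0.49 log units; beyond the scatter) and a 4.5-fold lower number from compound 1 to compound 3 (0.66 log units; beyond the scatter), both of which brought the prop-1-en-1-yl group onto the carbonyl carbon and lowered the number; compound 4 takes that group away again, so the number is expected to rise by roughly the same amount, a 2.9-fold higher number from compound 3 to compound 4 (0.46 log units; beyond the scatter). Compound 4 is therefore estimated at 160 nM, within a range of 70 nM to 400 nM.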

Compound 4, half-maximal inhibitory concentration: 310 nM
Estimate against measurement, compound 4: 1.9-fold (0.29 log units) below; low and high end bracket the measured number.
By their numbers in this assay, from the lowest: compound 3; then compounds 2, 1 and 4 (each within the scatter of the next).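

In this assay, isopropyl in place of prop-1-en-1-yl on the carbonyl carbon, a group of equal heavy-atom count without the double bond, gives a 5.6-fold higher number from compound 3 to compound 4 (0.75 log units; beyond the scatter). The saturated groups do not separate from one another, with a 1.8-fold higher number from compound 2 to compound 4 (0.26 log units; within the scatter) and a 1.2-fold higher number from compound 1 to compound 4 (0.09 log units; within the scatter), so among these four compounds only the prop-1-en-1-yl of compound 3 stands apart. Nothing measured here accounts for this difference. As far as these compounds go, whether an ethenyl, a cyclopropyl or a prop-1-yn-1-yl group on the same carbonyl carbon would stand with compound 3 or with the other compounds remains open.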